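The source may report more compounds than this note shows. Statements on the series, on what has been measured and on what is new or still open speak of the compounds shown alone.

Within the data shown here, compound 1, `ClCc1cccc(Cn2cnc3c(Cl)ncnc32)c1`, is the weaker of the two compounds measured so far: in a functional assay on RPMI-8226 cells (Homo sapiens) for cytotoxicity, read by sulforhodamine B assay, with a stated time of 48 h (a lower number here means a stronger inhibitor of growth, a higher number a weaker inhibitor of growth), compound 1 gives 16200 nM, the highest of the two numbers. Its nearest neighbour, compound 2, `ClCc1ccc(Cn2cnc3c(Cl)nc(Cl)nc32)cc1`, gives 3800 nM in this assay, a lower number by a margin beyond the scatter of repeated runs; the two structures differ in more than one place, so no single step can be read from that pair.

The next compound, compound 3, `Nc1nc(Cl)c2ncn(Cc3cccc(CCl)c3)c2n1`, is reached from compound 1 by a single change: amino in place of hydrogen on an aromatic carbon. Among the measured compounds shown here, no pair of measured compounds shows the same change, so there is no measured step to lean on. The step of a 2.0-fold lower number from compound 1 to compound 3 (0.31 log units; beyond the scatter) is therefore expected to be modest, a lowering of the number that may or may not exceed the scatter. On that basis compound 3 is estimated to give 8000 nM, with a range from 2000 nM to 30000 nM, in this assay.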

Compound 3, concentration for total growth inhibition: 11800 nM
Beside the measured number, compound 3's estimate is 1.5-fold (0.17 log units) below it; the range from low to high includes it.
By their numbers in this assay, from the lowest: compound 2; then compounds 3 and 1 (each within the scatter of the next).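

In this assay, amino in place of hydrogen on the aromatic carbon between two ring nitrogen atoms gives a 1.4-fold lower number from compound 1 to compound 3 (0.14 log units; within the scatter), so compound 1 and compound 3 cannot be told apart in this read-out. Among these compounds, this is the first single change measured, and it shows that this carbon can carry an amino group, with its added nitrogen, without a difference that stands clear of the scatter of repeated runs. Nothing measured on these compounds speaks to why the two read alike.

The compounds shown leave open whether a methylamino group, a hydroxyl group or a longer chain on this same carbon would also stay within the scatter or would move the number clear of it. They also leave open whether amino at this place would read the same way in a compound that differs elsewhere from compound 1.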